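The compounds below may be only part of what the source reports. "The series", "measured", "known", "first", "only" and "open" are said of these compounds alone.

Measured in an ADME assay on NHDF cells (Homo sapiens) for cytotoxicity, read by MTT assay, with a stated time of 72 h; on this read-out higher numbers stand for weaker inhibition and lower numbers for stronger inhibition:
- compound 1 `COc1cccc(/C=C2\CCC/C(=C\c3cccc(OC)c3OC)C2=O)c1`: 16400 nM
- compound 2 `COc1ccc(/C=C2\CCC/C(=C\c3cccc(OC)c3OC)C2=O)c(OC)c1`: > 50000 nM (a limit of the assay)
- compound 3 `COc1ccc(/C=C2\CCC/C(=C\c3cccc(Br)c3)C2=O)cc1OC`: 12400 nM

Compound 3 gives 12400 nM, and compound 1 gives 16400 nM, so these two values lie within the scatter of each other. Compound 2 gives > 50000 nM, which is a limit of the assay and not a number.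

Compound 4 `COc1ccc(/C=C2\CCC/C(=C\c3ccc(O)cc3)C2=O)cc1OC` carries 4-hydroxyphenyl in place of 3-bromophenyl on a double-bonded chain carbon bound to a double-bonded ring carbon. Among the compounds with values here, no measured pair differs in one place only, so the size of this step in this assay cannot be read from a direct precedent. The expectation rests instead on compound 3 at 12400 nM and on compound 1 at 16400 nM, and no change beyond the scatter is foreseen. The expected step of a 1.2-fold higher number from compound 3 to compound 4 (0.08 log units; within the scatter) therefore has no firm direction. Compound 4 is estimated at 15000 nM, with an expected range from 5000 nM to 45000 nM.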

Compound 4, half-maximal inhibitory concentration: 26100 nM
Compound 4: the middle estimate sits 1.7-fold (0.24 log units) below what was measured; the measured number falls inside the stated range.
By their numbers in this assay, from the lowest: compounds 3, 1 and 4 (each within the scatter of the next, the first and the last beyond it). At a limit, above all of these: compound 2.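

Within the data shown here, the exchange of 3-bromophenyl for 4-hydroxyphenyl on a double-bonded chain carbon bound to a double-bonded ring carbon provides the first one-place comparison in this assay, and it brings a 2.1-fold higher number from compound 3 to compound 4 (0.32 log units; beyond the scatter). The step is modest, but it shows that the number in this assay responds to a change at this position, here in the direction of weaker inhibition. Nothing shown gives a reason for this step.

The exchange alters both the substituent and its place on the phenyl ring, so the compounds shown do not separate the loss of the bromine from the gain of the hydroxyl. From the compounds shown here alone, it also remains open how this position would respond to an amine or a carboxylic acid on that phenyl ring in place of the hydroxyl.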